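Indole oxadiazoles against Jurkat proliferation

A few compounds are considered here, and "the series" means these few. Any claim that something is new, unique, unknown or untested is made for them only; others in the source may bear on it.

Compound 1 `COc1ccc2[nH]c(-c3nc(C)no3)cc2c1` carries a methoxy on the fused ring and a methyl on the oxadiazole. In a functional assay on Jurkat cells (Homo sapiens) for antiproliferative activity, read by WST assay, with a stated time of 72 h (on this read-out lower numbers stand for stronger inhibition and higher numbers for weaker inhibition), compound 1 gives 19900 nM. Compound 2 `Clc1ccc(-c2noc(-c3cc4ccccc4[nH]3)n2)cc1` carries a chlorophenyl on the oxadiazole and no methoxy. In this assay compound 2 reaches only the limit of the assay, > 50000 nM, and no number stands for it. Compound 2 thus stands at the limit of > 50000 nM in this assay, at which 1 of the 2 values shown sits, the upper edge of what the set shows.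

Compound 3 `COc1ccc2[nH]c(-c3nc(-c4ccc(Cl)cc4)no3)cc2c1` is not yet measured. It differs from compound 2 by methoxy in place of hydrogen on an aromatic carbon. Among the measured compounds shown here, no measured pair shares this change, so no step is at hand. In this assay the expected step of an at least 1.2-fold lower number from compound 2 to compound 3 (0.09 log units; that floor lies within the scatter) is modest, towards stronger inhibition or none beyond the scatter. Compound 3 is estimated at 40000 nM. For compound 3 the expected range runs from 15000 nM to 100000 nM.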

Compound 3, half-maximal inhibitory concentration: > 50000 nM
Compound 3 was reported as a limit; the forecaster's own chance of this, stated with the estimate: 45%; middle value at least 1.2-fold (0.09 log units) away from the limit.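

Among the compounds shown here, with the methoxy held in place, 4-chlorophenyl in place of methyl on an aromatic carbon of the oxadiazole gives an at least 2.5-fold higher number from compound 1 to compound 3 (0.40 log units; beyond the scatter) in this assay, the first readable step and one towards weaker inhibition. Methoxy in place of hydrogen on an aromatic carbon does not bring the chlorophenyl compound to a readable number: compound 3 gives only a limit of the assay, > 50000 nM, so the step from compound 2 cannot be read. The chlorophenyl compounds now both sit at the upper edge of the series: the limit of > 50000 nM in this assay, at which 2 of the 3 values shown sit.

On these data alone, how far the 4-chlorophenyl change lies beyond its floor, and whether methoxy matters at all with that group present, stays open. Also open, as far as these compounds go, is whether an ethyl or an aminomethyl in place of the methyl of compound 1 would keep a readable number.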